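Octylsulfonamido-benzoic acids: biaryl swap in two cores

The source may hold more compounds than are shown below. What is called first, only, known or untested is meant among the compounds shown, and "the series" means these compounds.

Measured in an assay on mitochondria (strain BALB/c) for inhibition of glycerol-3-phosphate acyltransferase 1, mitochondrial (Mus musculus), read by scintillation counting, with a stated time of 10 min; a higher number here means a weaker inhibitor, a lower number a stronger inhibitor:
compound 1 `CCCCCCCCS(=O)(=O)Nc1cc(-c2ccc(OC)cc2)ccc1C(=O)O` gives 13300 nM
compound 2 `CCCCCCCCS(=O)(=O)Nc1cc(-c2ccccc2F)ccc1C(=O)O` gives 47200 nM
compound 3 `CCCCCCCCS(=O)(=O)Nc1ccc(-c2ccc(OC)cc2)cc1C(=O)O` gives 19500 nM

Compound 3 has the same atoms as compound 1, joined differently; the difference between the two cores is not broken down here. Their values lie within the scatter of each other. Compound 2 arises from compound 1 by the change 2-fluorophenyl in place of 4-methoxyphenyl on an aromatic carbon and shows a 3.5-fold higher number from compound 1 to compound 2 (0.55 log units; beyond the scatter).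

Compound 4 `CCCCCCCCS(=O)(=O)Nc1ccc(-c2ccccc2F)cc1C(=O)O` is not yet measured. It arises from compound 3 by 2-fluorophenyl in place of 4-methoxyphenyl on an aromatic carbon, the same kind of change as that from compound 1 to compound 2, though the place differs: here meta to a carboxy group and para to a large group, rather than meta to a large group and para to a carboxy group. Because of a 3.5-fold higher number from compound 1 to compound 2 (0.55 log units; beyond the scatter), a step of similar size is expected for compound 4, a 3.3-fold higher number from compound 3 to compound 4 (0.52 log units; beyond the scatter), resting on one precedent only. Compound 4 is therefore estimated at 65000 nM, between 30000 nM and 150000 nM.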

Compound 4, half-maximal inhibitory concentration: 34600 nM
Compound 4: middle estimate off by 1.9-fold (0.27 log units), on the high side; the measured number falls inside the stated range.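

In this assay, 2-fluorophenyl in place of 4-methoxyphenyl gives a 1.8-fold higher number from compound 3 to compound 4 (0.25 log units; within the scatter), so on this core the step alone cannot be told from repeat-measurement noise. Set beside the step on the core of compound 1, it shows no measurable difference between the two cores: the same change on two cores in this assay, a 3.5-fold higher number (0.55 log units; beyond the scatter) from compound 1 to compound 2 and a 1.8-fold higher number (0.25 log units; within the scatter) from compound 3 to compound 4, 2.0-fold (0.30 log units) apart, within the scatter of two such steps. The change therefore carries across without evident dependence on the core, but two pairs cannot establish a constant step size, and they do not show that the change weakens inhibition on the core of compound 3.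

All four compounds keep the octyl chain and the carboxy group. Open, as far as these compounds go, is whether the step holds with a shorter chain, a tetrazole in place of the carboxy group, or a plain phenyl or 4-fluorophenyl as the swapped group.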